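The source may hold more compounds than are shown below. What is called first, only, known or untested is meant among the compounds shown, and "the series" means these compounds.

Measured so far in an ADME assay on HeLa cells (Homo sapiens) for cytotoxicity, read by MTT assay, with a stated time of 24 h; a higher number here means a weaker inhibitor, a lower number a stronger inhibitor:

Compound 1 `CCN(CC)C(=S)SC(=S)N(C)C`: > 5000000 nM (a limit of the assay)
Compound 2 `CCCCN1CCN(C(=S)SC(=S)N(C)C)CC1`: 4100000 nM

Within the data shown here, compound 2 carries the only actual number so far. Compound 1 reaches only the limit of > 5000000 nM, so it gives no exact value for comparison.

The next compound is compound 3 `CN(C)C(=S)SC(=S)N1CCN(C(=O)c2ccco2)CC1`, which has (furan-2-yl)carbonyl in place of butyl on an amine nitrogen in a ring. Among the measured compounds shown here, no step between measured compounds is available, so the change has no direct precedent. The expectation therefore rests on compound 2 at 4100000 nM. It also takes into account the limit reached by compound 1. Given so little data, no shift beyond the usual scatter is predicted in either direction. The expected change in this assay is a 1.2-fold lower number from compound 2 to compound 3 (0.07 log units; within the scatter), which is within that scatter. A result reported only as a limit remains a real possibility. The estimated value for compound 3 is 3500000 nM, with an expected range from 1500000 nM to 7000000 nM.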

Compound 3, half-maximal inhibitory concentration: 2380000 nM
The estimate for compound 3 lay 1.5-fold (0.17 log units) above the measured number; low and high end bracket the measured number.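

On the amine nitrogen in the ring, the series now has its first readable step in this assay: (furan-2-yl)carbonyl in place of butyl gives a 1.7-fold lower number from compound 2 to compound 3 (0.24 log units; within the scatter). This position therefore takes a swap from an open butyl chain with 0 hydrogen-bond acceptors to a larger group with a five-membered aromatic ring and 2 hydrogen-bond acceptors, with no shift beyond the scatter in this read-out. Compound 1 remains a limit and not a number, so this single step is the only comparison the series offers: the limit of > 5000000 nM in this assay, at which 1 of the 3 values shown sits.

One step does not show whether the read-out stays within the scatter for other groups on this nitrogen, such as a benzoyl group, a longer alkyl chain or a chain ending in a carboxylic acid. Also open, as far as these compounds go, is how far the furan ring and the carbonyl each contribute to the result, and an acetyl group on the same nitrogen would help to separate the two.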